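Amino for chloro: a repeated change on a shared core

The source may report more compounds than this note shows. Statements on the series, on what has been measured and on what is new or still open speak of the compounds shown alone.

Three compounds carry a measured value. Compound 1 `Nc1nc(Cl)c2ncn(Cc3ccc(CCl)cc3)c2n1`, compound 2 `ClCc1cccc(Cn2cnc3c(Cl)nc(Cl)nc32)c1` and compound 3 `ClCc1ccc(Cn2cnc3c(Cl)nc(Cl)nc32)cc1` were run in a functional assay on SF-268 cells (Homo sapiens) for cytotoxicity, read by sulforhodamine B assay, with a stated time of 48 h; a lower number here means a stronger inhibitor of growth, a higher number a weaker inhibitor of growth. In this assay compound 1 gives 8320 nM, compound 2 gives 6600 nM and compound 3 gives 5370 nM. Compound 2 and compound 3 have the same atoms joined differently; the difference between the two cores is not broken down here, and their two values lie within the usual scatter of each other.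

The change from compound 3 to compound 1 is amino in place of chloro on an aromatic carbon. That step gave a 1.5-fold higher number from compound 3 to compound 1 (0.19 log units; within the scatter).

Compound 4 `Nc1nc(Cl)c2ncn(Cc3cccc(CCl)c3)c2n1` is not yet measured. It stands to compound 2 as compound 1 stands to compound 3: amino in place of chloro on an aromatic carbon. Both occurrences of the change sit at the same place, word for word, so this is the same change, made twice among the compounds shown.

The step is expected to be a 1.5-fold higher number from compound 2 to compound 4 (0.18 log units; within the scatter) because its earlier occurrence gave a 1.5-fold higher number from compound 3 to compound 1 (0.19 log units; within the scatter). On that basis compound 4 is estimated at 10000 nM in this assay, with the expected range running from 5000 nM to 20000 nM.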

Compound 4, concentration for total growth inhibition: 10200 nM
Estimate against measurement, compound 4: 1.0-fold (0.01 log units) below, within the range that was stated.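

In this assay, amino in place of chloro on an aromatic carbon gave a 1.5-fold higher number from compound 2 to compound 4 (0.19 log units; within the scatter), and the two occurrences of the change on the two cores do not differ beyond the scatter: the same change on two cores in this assay, a 1.5-fold higher number (0.19 log units; within the scatter) from compound 3 to compound 1 and a 1.5-fold higher number (0.19 log units; within the scatter) from compound 2 to compound 4, 1.0-fold (0.00 log units) apart, within the scatter of two such steps. Among these compounds, neither step lies beyond the scatter, so the pair shows only that the same swap gives a step of matching size on both cores, not that amino weakens growth inhibition. The agreement rests on two closely related cores and a single read-out, and it does not show that the change would carry over to a core with a different side group.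

Open, from the compounds shown here alone, is whether another group on that same aromatic carbon, such as a methylamino or a methoxy group, would give a step beyond the scatter. Also open, going by these compounds, is whether the amino-for-chloro step would hold its size if the chloromethyl group gave way to a hydroxymethyl group or a longer chain.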